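Carboxy to diisopropylcarbamoyl on the shared core

The source may report more compounds than this note shows. Statements on the series, on what has been measured and on what is new or still open speak of the compounds shown alone.

The shared core is that of compound 1 `CC(=O)O[C@]1(C)/C=C/C(=O)/C(CO)=C\C[C@](C)(CCC=C(C)C)/C=C/[C@H]1OC(=O)C=C(C)C`, which in a functional assay on SMMC-7721 cells (Homo sapiens) for antiproliferative activity, read by MTT assay, with a stated time of 48 h (a lower number here means a stronger inhibitor, a higher number a weaker inhibitor), gives 3080 nM. Compound 2 `CC(C)=CCC[C@]1(C)/C=C/[C@@H](OC(=O)C=C(C)C)[C@](C)(O)/C=C/C(=O)/C(C(=O)O)=C\C1` carries a carboxy group where compound 1 carries hydroxymethyl. In this assay compound 2 returns > 10000 nM, which is a limit of the assay and not a number. Compound 3 `CC(C)=CCC[C@]1(C)/C=C/[C@@H](OC(=O)C=C(C)C)[C@](C)(O)/C=C/[C@H](O)/C(CO)=C\C1` in this assay returns > 40000 nM, again a limit rather than a number. Among the measured compounds shown here, compound 2 therefore stands at one of the two limits in the set, (the limit of > 10000 nM in this assay, at which 1 of the 3 values shown sits), and the only value with a number belongs to compound 1.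

Compound 4 `CC(C)=CCC[C@]1(C)/C=C/[C@@H](OC(=O)C=C(C)C)[C@](C)(O)/C=C/C(=O)/C(C(=O)N(C(C)C)C(C)C)=C\C1` is made from compound 2 by one change: diisopropylamino in place of hydroxy on a carbonyl carbon. Cut one bond further out, this reads carboxy to diisopropylcarbamoyl. For the measured compounds named here, no measured pair in the set shows this change, so the size of the step from compound 2 to compound 4 cannot be read from the data; a modest gain in this assay is expected, with a real chance that compound 4 also ends at a limit. The step expected from compound 2 to compound 4 is an at least 1.2-fold lower number from compound 2 to compound 4 (0.09 log units; that floor lies within the scatter). Compound 4 is estimated at 8000 nM, within 2000 nM to 30000 nM.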

Compound 4, half-maximal inhibitory concentration: 17200 nM
For compound 4 the middle estimate is 2.2-fold (0.33 log units) below the measured one; the measured number falls inside the stated range.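

Among the compounds shown here, no step from compound 2 to compound 4 can be read, because the value of compound 2 is a limit of the assay and not a number: the limit of > 10000 nM in this assay, at which 1 of the 4 values shown sits. The compounds shown leave open the size, and even the direction, of the effect of changing carboxy to diisopropylcarbamoyl on the shared core in this assay.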